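Methyl for Methylsulfanyl, Carried onto a Second Core

This account rests on a few compounds, and the source may have more. Where it says the series, first, only, none or still open, it means among the compounds named here.

Measured so far in a functional assay (Cavia porcellus) for antagonist activity at Serotonin 3 (5-HT3) receptor (Homo sapiens); a lower number here means a stronger inhibitor, a higher number a weaker inhibitor:
compound 1 `Cc1cccc(N2CCN(C3CN4CCC3CC4)C2=O)c1`, 12 nM
compound 2 `CSc1cccc(N2CCN(C3CN4CCC3CC4)C2=O)c1`, 214 nM
compound 3 `CSc1cccc(N2CCN(Cc3nc[nH]c3C)C2=O)c1`, 120 nM

Compound 1 and compound 2 share one core and differ only in methyl in place of methylsulfanyl on an aromatic carbon. That change produced an 18-fold lower number from compound 2 to compound 1 (1.25 log units; beyond the scatter). Compound 3 carries a different core; the difference between the two cores of compound 3 and compound 2 is not broken down here, and their values in this assay fall within the scatter of each other.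

Compound 4 `Cc1cccc(N2CCN(Cc3nc[nH]c3C)C2=O)c1` has not yet been measured. It stands to compound 3 as compound 1 stands to compound 2: methyl in place of methylsulfanyl on an aromatic carbon, the same change at the same place. The step from compound 3 to compound 4 is expected to be a 12-fold lower number from compound 3 to compound 4 (1.08 log units; beyond the scatter), a little smaller than the earlier one because an 18-fold lower number from compound 2 to compound 1 (1.25 log units; beyond the scatter) rests on a single pair on another core. Compound 4 is therefore estimated at 10 nM, between 3 nM and 40 nM.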

Compound 4, antagonist equilibrium constant: 45.7 nM
Compound 4: the middle estimate sits 4.6-fold (0.66 log units) below what was measured; measured number above the stated range.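

Carried onto the second core, methyl in place of methylsulfanyl on an aromatic carbon again lowered the number in this assay, with a 2.6-fold lower number from compound 3 to compound 4 (0.42 log units; beyond the scatter). The direction of the step held on both cores, but its size did not: the same change on two cores in this assay, an 18-fold lower number (1.25 log units; beyond the scatter) from compound 2 to compound 1 and a 2.6-fold lower number (0.42 log units; beyond the scatter) from compound 3 to compound 4, 6.8-fold (0.83 log units) apart, beyond the scatter of two such steps. With a single pair on each core, this shows that the size of the step differed between these two cores, but not what in the cores sets that size or how large the step would be on any further core.

The compounds shown leave open whether other groups on that aromatic carbon, such as chlorine, methoxy or a longer chain like ethyl, would also differ between the two cores. As far as these compounds go, an amine there is equally open.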